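This account rests on a few compounds, and the source may have more. Where it says the series, first, only, none or still open, it means among the compounds named here.

Of the compounds shown here, three have so far been tested in a functional assay on the whole organism with Mus musculus as the target; a higher number here means that more compound is needed for the effect, a lower number that less compound is needed. Compound 1, `O=C(CCC(=O)c1cccs1)NCCCO`, carries an open chain instead of a closed core; in this assay compound 1 reaches only > 300 mg/kg, which is a limit of the measurement and not a number. Compound 2, `COc1ccc(C23CCC(=O)N2CCCO3)cc1`, shares its core with compound 3, and in this assay compound 2 gives 139 mg/kg. Compound 3, `Cc1ccc(C23CCC(=O)N2CCCO3)c(C)c1`, gives in this assay < 150 mg/kg, again a limit of the measurement rather than a number. Among the measured compounds shown here, compound 2 therefore stands as the only true number among the three results, the others sitting at the limit of < 150 mg/kg in this assay, at which 1 of the 3 values shown sits, and at the limit of > 300 mg/kg in this assay, at which 1 of the 3 values shown sits.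

Compound 4, `O=C1CCC2(c3ccc(Cl)cc3)OCCCN12`, has not yet been measured in this assay. It differs from compound 2 in one place: chloro in place of methoxy on an aromatic carbon. For the measured compounds named here, no measured pair shows what such an exchange does here, so the step expected from compound 2 to compound 4 is a 1.1-fold lower number from compound 2 to compound 4 (0.03 log units; within the scatter), small and within the usual scatter, with no clear direction. Compound 4 is thus expected to give about 130 mg/kg in this assay, most likely between 60 mg/kg and 280 mg/kg.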

Compound 4, dose for half-maximal effect: 91.7 mg/kg
The estimate for compound 4 lay 1.4-fold (0.15 log units) above the measured number, within the range that was stated.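

Chloro in place of methoxy, on an aromatic carbon para to a large group, gives the first step that can be read at this position: in this assay it is a 1.5-fold lower number from compound 2 to compound 4 (0.18 log units; within the scatter). Compound 2 and compound 4 therefore cannot be told apart in this test, so this position tolerates the exchange of methoxy, with the oxygen counted as a hydrogen-bond acceptor, for a single chlorine atom without a change that stands clear of the usual scatter. Nothing in the data at hand offers an explanation for this step.

As far as these compounds go, whether the position tolerates very different groups, such as an amine, a carboxylic acid or a longer chain, remains open. A single pair also cannot tell whether the same exchange would behave alike on another carbon of the aromatic ring.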